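Swapping a carboxy-indole group for benzothiophene

This account rests on a few compounds, and the source may have more. Where it says the series, first, only, none or still open, it means among the compounds named here.

- Compound 1 `Cn1c(=O)c(S(=O)(=O)c2ccc(F)cc2F)cc2cnc(Nc3ccc4[nH]c(C(=O)O)cc4c3)nc21` gives 10000 nM
- Compound 2 `Cn1c(=O)c(S(=O)(=O)c2ccc(C(=O)O)cc2)cc2cnc(Nc3ccc4[nH]ccc4c3)nc21` gives 5000 nM
- Compound 3 `Cn1c(=O)c(S(=O)(=O)c2ccccc2)cc2cnc(Nc3cnc4[nH]ccc4c3)nc21` gives 5000 nM

All three compounds were tested in a functional assay on K562 cells (Homo sapiens) for inhibition, read by trypan blue exclusion, with a stated time of 72 h; a lower number here means a stronger inhibitor, a higher number a weaker inhibitor. Compound 1 stands within the usual scatter of both compound 2 and compound 3, so these values cannot separate the three.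

Compound 4 `Cn1c(=O)c(S(=O)(=O)c2ccc(F)cc2F)cc2cnc(Nc3ccc4sccc4c3)nc21` has 1-benzothiophen-5-yl in place of the 2-carboxy-1H-indol-5-yl of compound 1, on a nitrogen on an aromatic ring. The change counts as follows: 1-benzothiophen-5-yl in place of 2-carboxy-1H-indol-5-yl on a nitrogen on an aromatic ring.

Among the compounds with values here, no two measured compounds differ in one place only, so nothing here isolates the effect of this swap. The evidence is indirect and weak. Compound 3 gives 5000 nM without any carboxy group, so removing that group need not bring a large step. A modest move towards a lower number is therefore expected, possibly not much beyond the scatter. The estimated change is a 3.3-fold lower number from compound 1 to compound 4 (0.52 log units; beyond the scatter). For compound 4 the estimated value is 3000 nM, with an expected range from 500 nM to 10000 nM.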

Compound 4, half-maximal inhibitory concentration: 500 nM
For compound 4 the middle estimate is 6.0-fold (0.78 log units) above the measured one; the range from low to high includes it.
By their numbers in this assay, from the lowest: compound 4; then compounds 2, 3 and 1 (each within the scatter of the next).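

In this assay, within the data shown here, putting 1-benzothiophen-5-yl in place of 2-carboxy-1H-indol-5-yl on a nitrogen on an aromatic ring gives a 20-fold lower number from compound 1 to compound 4 (1.30 log units; beyond the scatter) and this is the first comparison here in which only one place differs. The earlier compounds shown here differed in several places and stood within the scatter of each other, whereas this step shows that the group at this position can move the number by a large amount. No measurement here bears on the reason for the step.

The swap removes the carboxy group and also replaces the ring nitrogen and its hydrogen with sulfur, and the compounds shown do not separate these two changes. A 2-carboxy-1-benzothiophen-5-yl group on the core of compound 4 would help to separate them, and a methyl ester in place of the carboxy group would test that group further.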